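The compounds below may be only part of what the source reports. "The series", "measured", "known", "first", "only" and "open" are said of these compounds alone.

In a functional assay on MDA-MB-231 cells (Homo sapiens) for antiproliferative activity, read by MTT assay, with a stated time of 24 h (on this read-out lower numbers stand for stronger inhibition and higher numbers for weaker inhibition), compound 1 `O=C(NNc1cccc(Cl)c1)c1ccccc1NS(=O)(=O)c1cnc(O)nc1O` gives 11800 nM and compound 2 `CCCCOc1ccc(C(=O)NNC(=O)c2ccccc2NS(=O)(=O)c2cnc(O)nc2O)cc1` gives 6830 nM and these two values lie within the usual scatter of each other. Compound 3 `O=C(NNC(=O)c1ccccc1NS(=O)(=O)c1cnc(O)nc1O)c1ccccc1Cl` differs from compound 2 in one place: 2-chlorophenyl in place of 4-butoxyphenyl on a carbonyl carbon with 2-chlorophenyl in place of 4-butoxyphenyl on a carbonyl carbon. For the measured compounds named here, no measured pair of compounds shows a comparable swap, so no step beyond the scatter is expected in this assay in either direction. The estimated change is a 1.2-fold higher number from compound 2 to compound 3 (0.07 log units; within the scatter) and it stays within the scatter. For compound 3 the expected value is 8000 nM with an estimated range from 2500 nM to 25000 nM around it.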

Compound 3, half-maximal inhibitory concentration: 8310 nM
Beside the measured number, compound 3's estimate is 1.0-fold (0.02 log units) below it; the measured number falls inside the stated range.
By their numbers in this assay, from the lowest: compounds 2, 3 and 1 (each within the scatter of the next).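

In this assay, for the compounds shown here, 2-chlorophenyl in place of 4-butoxyphenyl on a carbonyl carbon gives a 1.2-fold higher number from compound 2 to compound 3 (0.09 log units; within the scatter) and so, at this position, losing the butoxy chain for a chlorine-bearing ring shows no step beyond the scatter. (2-chlorophenyl)carbonyl in place of 3-chlorophenyl on an amine nitrogen gives a 1.4-fold lower number from compound 1 to compound 3 (0.15 log units; within the scatter) and likewise shows no such step. Nothing measured here gives a reason for these results. Going by these compounds, whether an amine or a carboxylic acid on the phenyl ring at this carbonyl carbon would give a step beyond the scatter remains open.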